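This account rests on a few compounds, and the source may have more. Where it says the series, first, only, none or still open, it means among the compounds named here.

Working notes on the series. Compound 1 `COc1cc(C(=O)c2sc(-c3ccc(Cl)cc3)cc2N)cc(OC)c1OC` carries a 4-chlorophenyl on an aromatic carbon of the five-membered aromatic ring of the shared core. Within the data shown here, in a functional assay on CCRF-CEM cells (Homo sapiens) for antiproliferative activity (a lower number here means a stronger inhibitor, a higher number a weaker inhibitor), compound 1 gives 70 nM, the highest of the three numbers measured so far. Compound 2 `COc1cc(C(=O)c2sc(-c3ccccc3)cc2N)cc(OC)c1OC`, hydrogen in place of chloro on an aromatic carbon, gives 4.5 nM in this assay. Compound 3 `COc1cc(C(=O)c2sc(-c3ccccc3Cl)cc2N)cc(OC)c1OC`, 2-chlorophenyl in place of 4-chlorophenyl on an aromatic carbon, gives 16 nM in this assay. The measured steps are a 16-fold lower number from compound 1 to compound 2 (1.19 log units; beyond the scatter), a 4.4-fold lower number from compound 1 to compound 3 (0.64 log units; beyond the scatter) and a 3.6-fold higher number from compound 2 to compound 3 (0.55 log units; beyond the scatter).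

Compound 4 `COc1cc(C(=O)c2sc(-c3ccsc3)cc2N)cc(OC)c1OC` has not yet been measured in this assay. It differs from compound 1 as follows: thiophen-3-yl in place of 4-chlorophenyl on an aromatic carbon. Among the measured compounds shown here, two measured steps bear on it. Removing the chloro altogether, a 16-fold lower number from compound 1 to compound 2 (1.19 log units; beyond the scatter), was the large one; moving it to the 2-position, a 4.4-fold lower number from compound 1 to compound 3 (0.64 log units; beyond the scatter), was modest. The entering thiophen-3-yl has no chloro, so the step from compound 1 to compound 2 is the closer precedent, though the ring that enters is not phenyl, which argues for a somewhat smaller step. For compound 4 a value of 8 nM is expected in this assay, within a range of 2.5 nM to 25 nM. That estimate means an 8.8-fold lower number from compound 1 to compound 4 (0.94 log units; beyond the scatter), a clear drop in number from compound 1.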

Compound 4, half-maximal inhibitory concentration: 9.6 nM
Beside the measured number, compound 4's estimate is 1.2-fold (0.08 log units) below it, and the stated range covers the measured number.
By their numbers in this assay, from the lowest: compound 2; then compounds 4 and 3 (each within the scatter of the next); then compound 1.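

Thiophen-3-yl in place of 4-chlorophenyl gives a 7.3-fold lower number from compound 1 to compound 4 (0.86 log units; beyond the scatter) in this assay, so this position on the shared core also accepts a five-membered aromatic ring with 1 sulfur, not only a six-membered aromatic ring of carbon, without returning to the high number of compound 1; set against the unsubstituted phenyl, the same ring gives a 2.1-fold higher number from compound 2 to compound 4 (0.33 log units; beyond the scatter), a modest step that leaves compound 2 with the lowest number of the four. The comparison with the chlorinated ring of compound 3 gives a 1.7-fold lower number from compound 3 to compound 4 (0.22 log units; within the scatter), so thiophen-3-yl and 2-chlorophenyl cannot be told apart at this position in this assay. Nothing measured here accounts for any of these differences.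

Still open, going by these compounds, is whether the tolerance extends to other aromatic rings, such as thiophen-2-yl, furan-3-yl or pyridin-3-yl, or is particular to thiophen-3-yl. Also open, on these data alone, is what a methyl or methoxy group, or a chloro, would do when carried on the thiophen-3-yl ring itself, and whether a saturated ring such as morpholine or a carboxylic acid on the phenyl would hold the number near that of compound 2.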